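Solubility notes: oxazolidinedione to thiazolidinedione methyl

The source may hold more compounds than are shown below. What is called first, only, known or untested is meant among the compounds shown, and "the series" means these compounds.

Compound 1 `CC(C)/C(=C1\C(=O)NC(=O)N1C)c1ccc(-c2ccc3cccc(F)c3c2)[nH]c1=O` gives 11100 nM in a physicochemical assay for solubility, measured as kinetic solubility, at pH 2; a higher number here means a more soluble compound, a lower number a less soluble compound. Compound 2 `CC(C)[C@@H](c1ccc(-c2ccc3cccc(F)c3c2)[nH]c1=O)[C@H]1OC(=O)NC1=O` gives 5400 nM, and compound 3 `CC(C)[C@@H](c1ccc(-c2ccc3cccc(F)c3c2)[nH]c1=O)[C@@H]1OC(=O)NC1=O` gives 6900 nM; compound 3 thus stands second highest of the three numbers, nearest compound 2 and furthest from compound 1, both gaps within the scatter. Among the compounds with values here, the only measured step that changes one place, a 1.3-fold higher number from compound 2 to compound 3 (0.11 log units; within the scatter), rests on the fact that compounds 2 and 3 differ only in the configuration as drawn and shows nothing beyond the scatter. Compound 4 `CC(C)[C@H](C[C@H]1SC(=O)NC1=O)c1ccc(-c2ccc3cccc(F)c3c2)[nH]c1=O` differs from compound 3 by (2,4-dioxo-1,3-thiazolidin-5-yl)methyl in place of 2,4-dioxo-1,3-oxazolidin-5-yl on a saturated chain carbon bound to an aromatic carbon and a saturated chain carbon. Within the data shown here, no measured step covers this exchange; the one step available says only that a small change left the number where it was. For compound 4 the expected step is a 1.4-fold lower number from compound 3 to compound 4 (0.14 log units; within the scatter). Compound 4 is therefore estimated at 5000 nM, with a range from 2500 nM to 10000 nM.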

Compound 4, solubility: 4900 nM
Compound 4: the middle estimate sits 1.0-fold (0.01 log units) above what was measured; the measured number falls inside the stated range.
By their numbers in this assay, from the lowest: compounds 4, 2, 3 and 1 (each within the scatter of the next, the first and the last beyond it).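

In this assay, (2,4-dioxo-1,3-thiazolidin-5-yl)methyl in place of 2,4-dioxo-1,3-oxazolidin-5-yl gives a 1.4-fold lower number from compound 3 to compound 4 (0.15 log units; within the scatter) and a 1.1-fold lower number from compound 2 to compound 4 (0.04 log units; within the scatter). The earlier step at this saturated chain carbon changed configuration only; this one changes the group itself, and the number still stays within the scatter. Nothing measured here gives a cause for these steps.

Compound 4 changes the ring and lengthens the link in a single exchange, so neither change can be read alone. From the compounds shown here alone, how an amine or a carboxylic acid on this saturated chain carbon would read in this assay remains open.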